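The compounds below may be only part of what the source reports. "The series", "measured", "known", "first", "only" and "open" are said of these compounds alone.

Among the measured compounds shown here, in a physicochemical assay for lipophilicity (a lower number here means a more polar compound, a higher number a more lipophilic compound), compound 1 `CCCCS(=O)(=O)c1ccc(O)c(C(=O)Nc2ccc(C(F)(F)F)cc2)c1` stands at 4.14, the lower of the two numbers so far. Compound 2 `CCCCCCCCCCCCS(=O)(=O)c1ccc(O)c(C(=O)Nc2ccc(C(F)(F)F)cc2)c1` stands at 8.46. Compound 3 `CCCCCCCCCCS(=O)(=O)c1ccc(O)c(C(=O)Nc2ccc(C(F)(F)F)cc2)c1` is not yet measured and differs from compound 1 by hexyl in place of hydrogen on a saturated chain carbon, four bonds along the chain from a sulfonyl sulfur. For the measured compounds named here, the only measured step that bears on it places octyl at the same position, giving a number 4.32 log units higher from compound 1 to compound 2 (beyond the scatter). Hexyl is the shorter chain, so a large step in the same direction, but smaller than that one, is expected in this assay. The estimated step is a number 3.24 log units higher from compound 1 to compound 3 (beyond the scatter). For compound 3 the expected value is 7.38, with an estimated range of 6.95 to 7.8.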

Compound 3, partition coefficient: 7.38
Beside the measured number, compound 3's estimate shows no gap at the digits printed; measured number inside the range.
By their numbers in this assay, from the lowest: compound 1; then compound 3; then compound 2.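

In this assay, the chain position now has an intermediate point: a number 3.24 log units higher from compound 1 to compound 3 (beyond the scatter), while a number 1.08 log units lower from compound 2 to compound 3 (beyond the scatter). Across compounds 1, 3 and 2, the number changes by the same amount per chain carbon, and none of the three departs from this even rise. No supporting measurement accounts for this rise.

Going by these compounds, whether the even rise continues beyond the chain of compound 2 remains open. Also open, on these data alone, is how a branched chain, or an amine or carboxylic acid at the chain end, would fare at this position.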